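This account rests on a few compounds, and the source may have more. Where it says the series, first, only, none or still open, it means among the compounds named here.

Working notes on the ester series in an ADME assay on a cell-free system (plasma, Cavia porcellus, strain Dunkin-Hartley) for metabolic stability, read by HPLC, tested at 5 mM; on this read-out lower numbers stand for a shorter-lived compound and higher numbers for a longer-lived compound.

Compound 1 `C[C@@H](O)[C@H]1C(=O)N2C(C(=O)OCOC(=O)OC3Cc4ccccc4C3)=C(S[C@@H]3CN[C@H](C(=O)N(C)C)C3)[C@H](C)[C@H]12` gives 0.015 h in this assay. Going by the values given here, compound 2 `C[C@@H](O)[C@H]1C(=O)N2C(C(=O)OCOC(=O)OC3CCCc4ccccc4C3)=C(S[C@@H]3CN[C@H](C(=O)N(C)C)C3)[C@H](C)[C@H]12` gives 0.0317 h and so stands at the higher of the two single numbers, with compound 1 as its nearest neighbour; the step of a 2.1-fold higher number from compound 1 to compound 2 (0.32 log units; beyond the scatter) is the only single-change step measured so far. Compound 3 `CC(C)OC(=O)OC(C)OC(=O)C1=C(S[C@@H]2CN[C@H](C(=O)N(C)C)C2)[C@H](C)[C@@H]2[C@@H]([C@@H](C)O)C(=O)N12` has two entries, 0.0233 h; 0.108 h (2 entries), and the repeat entries the several entries of compound 3 in this assay, 0.0233 h; 0.108 h (2 entries) lie far apart, which warns that any one number in this assay carries wide uncertainty.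

Compound 4 `C[C@@H](O)[C@H]1C(=O)N2C(C(=O)OCOC(=O)OC3CCc4ccccc4C3)=C(S[C@@H]3CN[C@H](C(=O)N(C)C)C3)[C@H](C)[C@H]12` differs from compound 2 in the ester portion: a group of 10 heavy atoms (10 carbon; one six-membered non-aromatic ring of carbon only, one six-membered aromatic ring of carbon only) in place of a group of 11 heavy atoms (11 carbon; one six-membered aromatic ring of carbon only, one seven-membered non-aromatic ring of carbon only), on an oxygen next to a carbonyl group. The change runs in the same region as the step from compound 1 to compound 2, where a larger ring on the oxygen next to the carbonyl group went with the longer half-life, and the 1,2,3,4-tetrahydronaphthalen-2-yl group sits between the two in size. The step of a 1.4-fold lower number from compound 2 to compound 4 (0.16 log units; within the scatter) is therefore expected to be small, toward a shorter half-life, and likely within the scatter. Compound 4 is estimated at 0.022 h, with a range of 0.01 h to 0.05 h.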

Compound 4, half-life in the Cavia porcellus assay: 0.0283 h
For compound 4 the middle estimate is 1.3-fold (0.11 log units) below the measured one; the measured number falls inside the stated range.
By their numbers in the Cavia porcellus assay, from the lowest: compounds 1, 4 and 2 (each within the scatter of the next, the first and the last beyond it).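

In the Cavia porcellus assay the result reads as a 1.1-fold lower number from compound 2 to compound 4 (0.05 log units; within the scatter) and as a 1.9-fold higher number from compound 1 to compound 4 (0.28 log units; within the scatter), so 1,2,3,4-tetrahydronaphthalen-2-yl on an oxygen next to a carbonyl group cannot be told apart from either of the other two groups, and no graded series by ring can be read from compounds 1, 2 and 4. In a physicochemical assay for metabolic stability, read by HPLC, with a stated time of 120 min, at pH 6, tested at 100 uM (on this read-out higher numbers stand for a more stable compound and lower numbers for a less stable compound), compound 2 gives 96% and compound 4 gives 93%, which is a number 3 percentage points lower from compound 2 to compound 4 (within the scatter), so this change leaves the pair unresolved on that read-out as well. Repeat entries on another ester call for caution even with the one step beyond the scatter: the several entries of compound 3 in the Cavia porcellus assay, 0.0233 h; 0.108 h (2 entries)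

Open, as far as these compounds go, is whether an amine or a carboxylic acid on this group, or a longer open chain in its place, would shift the half-life beyond the scatter.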